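A few compounds are considered here, and "the series" means these few. Any claim that something is new, unique, unknown or untested is made for them only; others in the source may bear on it.

Compound 3 `CC(=O)NCCS(=O)(=O)NC(=O)c1ccc(Nc2nc(NC3(c4ccc(Cl)cc4)CC3)nc(OCC(F)(F)F)n2)cc1` stands lowest of the three compounds measured in a physicochemical assay for permeability, using PAMPA, at pH 7.4 (a higher number here means that the compound crosses the layer faster, a lower number that the compound crosses the layer more slowly), giving 7 nm/s, while compound 1 `O=C(NS(=O)(=O)c1ccccc1)c1ccc(Nc2nc(NC3(c4ccc(Cl)cc4)CC3)nc(OCC(F)(F)F)n2)cc1` gives 182 nm/s and compound 2 `O=C(NS(=O)(=O)c1ccc(F)cc1)c1ccc(Nc2nc(NC3(c4ccc(Cl)cc4)CC3)nc(OCC(F)(F)F)n2)cc1` gives 193 nm/s. The step of a 1.1-fold higher number from compound 1 to compound 2 (0.03 log units; within the scatter) is negligible, whereas a 26-fold lower number from compound 1 to compound 3 (1.41 log units; beyond the scatter) and a 28-fold lower number from compound 2 to compound 3 (1.44 log units; beyond the scatter) are both large. Compound 4 `CC(C)NC(=O)NCCS(=O)(=O)NC(=O)c1ccc(Nc2nc(NC3(c4ccc(Cl)cc4)CC3)nc(OCC(F)(F)F)n2)cc1` differs from compound 3 by isopropylamino in place of methyl on a carbonyl carbon. Going by the values given here, no measured step changes the same part of the molecule in the same way; the two large steps only show that the sulfonyl substituent governs this assay, and compound 4 keeps the 2-acetamidoethyl-type chain of compound 3 with a longer end. The expected outcome is therefore a step of a 1.4-fold lower number from compound 3 to compound 4 (0.15 log units; within the scatter), no larger than the scatter. Compound 4 is estimated at 5 nm/s, within 2 nm/s to 14 nm/s.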

Compound 4, apparent permeability: 45 nm/s
Compound 4: the middle estimate sits 9.0-fold (0.95 log units) below what was measured; the measured number lies above the stated range.
By their numbers in this assay, from the lowest: compound 3; then compound 4; then compounds 1 and 2 (each within the scatter of the next).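

In this assay the far end of the chain on the sulfonyl sulfur matters: isopropylamino in place of methyl on a carbonyl carbon gives a 6.4-fold higher number from compound 3 to compound 4 (0.81 log units; beyond the scatter), so this position is not silent. The gain is partial, since a 4.3-fold lower number from compound 2 to compound 4 (0.63 log units; beyond the scatter) and a 4.0-fold lower number from compound 1 to compound 4 (0.61 log units; beyond the scatter) remain beyond the scatter. Nothing available accounts for the rise. Open, going by these compounds, is whether a longer alkyl group or a carboxylic acid in place of isopropylamino would shift the number further, and whether any such chain could match phenyl on the sulfonyl sulfur.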